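The compounds below may be only part of what the source reports. "The series", "measured", "known", "first", "only" and "open" are said of these compounds alone.

In a functional assay on SF-268 cells (Homo sapiens) for cytotoxicity, read by sulforhodamine B assay, with a stated time of 48 h (a lower number here means a stronger inhibitor of growth, a higher number a weaker inhibitor of growth), the three measured compounds stand close together. Compound 3 `ClCc1ccc(Cn2cnc3c(Cl)nc(Cl)nc32)cc1` gives 2510 nM, and compound 2 `ClCc1cccc(Cn2cnc3c(Cl)nc(Cl)nc32)c1`, whose core carries the same atoms joined differently, gives 2510 nM; the difference between the two cores is not broken down here. Compound 1 `Nc1nc(Cl)c2ncn(Cc3ccc(CCl)cc3)c2n1` gives 1860 nM, and the step of a 1.3-fold lower number from compound 3 to compound 1 (0.13 log units; within the scatter) comes from the change (amino in place of chloro on an aromatic carbon). Compound 4 `Nc1nc(Cl)c2ncn(Cc3cccc(CCl)c3)c2n1` is not yet measured in this assay. It arises from compound 2 by the change (amino in place of chloro on an aromatic carbon), the same change that turned compound 3 into compound 1. Resting on that single measured step, compound 4 is expected to sit near compound 2, with an estimated step of a 1.3-fold lower number from compound 2 to compound 4 (0.12 log units; within the scatter), and its value in this assay is estimated at 1900 nM, between 900 nM and 4000 nM.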

Compound 4, concentration for 50% growth inhibition: 3020 nM
Estimate against measurement, compound 4: 1.6-fold (0.20 log units) below, and the stated range covers the measured number.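

In this assay, amino in place of chloro on an aromatic carbon gives a 1.2-fold higher number from compound 2 to compound 4 (0.08 log units; within the scatter), and set beside the earlier step on the other core, the two results cannot be told apart: the same change on two cores in this assay, a 1.3-fold lower number (0.13 log units; within the scatter) from compound 3 to compound 1 and a 1.2-fold higher number (0.08 log units; within the scatter) from compound 2 to compound 4, 1.6-fold (0.21 log units) apart, within the scatter of two such steps

Within these two pairs, the change therefore carries from one core to the other, and in both it leaves the growth-inhibition number within the scatter. For the compounds shown here, this does not show that the change is without effect in general, since it rests on only two pairs in a single assay, and a small effect could lie hidden in the scatter.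

The compounds shown leave open whether a methylamino group, a methoxy group or a longer alkylamine on that same aromatic carbon would behave like amino.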